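This account rests on a few compounds, and the source may have more. Where it says the series, first, only, none or still open, it means among the compounds named here.

Measured so far in a functional assay on UO-31 cells (Homo sapiens) for cytotoxicity, read by sulforhodamine B assay, with a stated time of 48 h; a higher number here means that more compound is tolerated, a lower number that less compound is tolerated:

- Compound 1 `ClCc1ccc(Cn2cnc3c(Cl)ncnc32)cc1` gives a limit of the assay, > 100000 nM.
- Compound 2 `ClCc1ccc(Cn2cnc3nc(Cl)nc(Cl)c32)cc1` gives 5620 nM.
- Compound 3 `ClCc1ccc(Cn2cnc3c(Cl)nc(Cl)nc32)cc1` gives 66100 nM.

All three carry the same side chain on a shared two-ring core and differ only in how that core is substituted with chloro. Compound 2 has the lowest number of the two numbers given, and its nearest neighbour is compound 3, which sits well beyond the scatter. How the cores of compound 2 and compound 3 differ is not broken down here. From compound 3 to compound 1 one change is made: hydrogen in place of chloro on an aromatic carbon. That step gave an at least 1.5-fold higher number from compound 3 to compound 1 (0.17 log units; that floor lies within the scatter), a floor set by the limit of > 100000 nM in this assay, at which 1 of the 3 values shown sits.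

Compound 4 `ClCc1ccc(Cn2cnc3ncnc(Cl)c32)cc1` is not yet measured. It arises from compound 2 by the same change: hydrogen in place of chloro on an aromatic carbon. Since the place of the change is the same word for word, the same kind of rise in the number is expected. Compound 4 is expected to give 20000 nM, most likely between 6000 nM and 80000 nM. The expected step is a 3.6-fold higher number from compound 2 to compound 4 (0.55 log units; beyond the scatter), resting on the value that compound 2 gives, 5620 nM, and on an at least 1.5-fold higher number from compound 3 to compound 1 (0.17 log units; that floor lies within the scatter).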

Compound 4, concentration lethal to 50% of the cells: > 100000 nM
Compound 4 was reported as a limit; the forecaster's own chance of this, stated with the estimate: 10%; middle value at least 5.0-fold (0.69 log units) from the limit.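

In this assay, putting hydrogen in place of chloro on an aromatic carbon gave an at least 17-fold higher number from compound 2 to compound 4 (1.25 log units; beyond the scatter), a large rise on this core. The rise is clear on this core only, since the step on the other core has a floor that lies within the scatter, and so the change cannot be said to carry over with the same size, or to be larger on one core than on the other: the same change on two cores in this assay, an at least 1.5-fold higher number (0.17 log units; that floor lies within the scatter) from compound 3 to compound 1 and an at least 17-fold higher number (1.25 log units; beyond the scatter) from compound 2 to compound 4; the limit leaves it open whether they differ Both steps end on a limit and not on a number, which means their true sizes stay unknown: the limit of > 100000 nM in this assay, at which 2 of the 4 values shown sit.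

The compounds shown carry only chloro or hydrogen at the changed places, so what an amine or a methoxy group would do there stays open. From the compounds shown here alone, all four also share one side chain, and whether the step would hold with a longer chain in its place is equally open.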